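This account rests on a few compounds, and the source may have more. Where it says the series, first, only, none or still open, it means among the compounds named here.

Working notes on the series. All three measured compounds share one core and are compared in a functional assay on HL-60 cells (Homo sapiens) for antiproliferative activity, read by XTT assay, with a stated time of 72 h; a lower number here means a stronger inhibitor, a higher number a weaker inhibitor. Compound 1, `COc1ncnc2c1c(-c1ccsc1)cn2[C@@H]1O[C@H](CO)[C@@H](O)[C@H]1O`, gives 130 nM and holds the lowest number of the three. Compound 2, `CN(C)c1ncnc2c1c(-c1ccsc1)cn2[C@@H]1O[C@H](CO)[C@@H](O)[C@H]1O`, gives 1920 nM, and compound 3, `C#Cc1cn([C@@H]2O[C@H](CO)[C@@H](O)[C@H]2O)c2ncnc(C)c12`, gives 1110 nM. Among the measured compounds shown here, the only step between close neighbours, a 15-fold higher number from compound 1 to compound 2 (1.17 log units; beyond the scatter), concerns a different group on the shared core and says nothing about the five-membered aromatic ring attached to it. Compound 3 differs from compound 1 in more than one place, so its higher value cannot be tied to a single change.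

Compound 4, `COc1ncnc2c1c(-c1ccoc1)cn2[C@@H]1O[C@H](CO)[C@@H](O)[C@H]1O`, differs from compound 1 by furan-3-yl in place of thiophen-3-yl on an aromatic carbon. For the measured compounds named here, no measured pair changes this group, so no step bears directly on it; the leaving and entering rings are counted alike apart from the hetero atom. The step in this assay is therefore expected to be a 1.5-fold higher number from compound 1 to compound 4 (0.19 log units; within the scatter), most likely none beyond the scatter. Compound 4 is estimated at 200 nM, with a range from 80 nM to 500 nM.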

Compound 4, half-maximal inhibitory concentration: 150 nM
Beside the measured number, compound 4's estimate is 1.3-fold (0.12 log units) above it; the range from low to high includes it.
By their numbers in this assay, from the lowest: compounds 1 and 4 (each within the scatter of the next); then compounds 3 and 2 (each within the scatter of the next).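

In this assay, among the compounds shown here, furan-3-yl in place of thiophen-3-yl gives a 1.2-fold higher number from compound 1 to compound 4 (0.06 log units; within the scatter), the first direct reading at this position on the shared core. With methoxy held constant, the exchange of sulfur for oxygen as the hetero atom of this five-membered aromatic ring leaves the two compounds within the scatter of each other. No measurement bears on the reason for this result.

Going by these compounds, it remains open whether a phenyl ring, an amine or a longer alkyl chain at this position would also stay within the scatter of compound 1. On these data alone, it is also open whether furan-3-yl and thiophen-3-yl would still read alike with dimethylamino on the core, the change that gives a 15-fold higher number from compound 1 to compound 2 (1.17 log units; beyond the scatter) in the thiophen-3-yl pair.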